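The source may report more compounds than this note shows. Statements on the series, on what has been measured and on what is new or still open speak of the compounds shown alone.

Measured compounds:
compound 1 `CCO/N=C1/C(=O)N(CCCn2cc(CN3CCC[C@@H]4CN(c5c(F)cc6c(=O)c(C(=O)O)cn(C7CC7)c6c5OC)C[C@@H]43)nn2)c2ccccc21`, 16 ug/mL
compound 2 `CO/N=C1/C(=O)N(CCCn2cc(CN3CCC[C@@H]4CN(c5c(F)cc6c(=O)c(C(=O)O)cn(C7CC7)c6c5OC)C[C@@H]43)nn2)c2ccc(F)cc21`, 4 ug/mL
compound 3 `CO/N=C1/C(=O)N(CCCn2cc(CN3CCC[C@@H]4CN(c5c(F)cc6c(=O)c(C(=O)O)cn(C7CC7)c6c5OC)C[C@@H]43)nn2)c2ccccc21`, 16 ug/mL

In an ADME assay on Vero cells (Chlorocebus sabaeus) for cytotoxicity, read by MTT assay, with a stated time of 72 h (a higher number here means that more compound is tolerated, a lower number that less compound is tolerated), compound 3 gives 16 ug/mL and compound 1 gives 16 ug/mL; the two differ by methyl in place of hydrogen on a saturated chain carbon bound to an oxygen on an unsaturated carbon, and the step of no change at the digits printed from compound 3 to compound 1 (within the scatter). Compound 2 differs from compound 3 by fluoro in place of hydrogen on an aromatic carbon, and in this assay compound 2 gives 4 ug/mL, so that the step of a 4.0-fold higher number from compound 2 to compound 3 (0.60 log units; beyond the scatter). Compound 2 thus has the lowest number of the three, with its steps to compound 1 and to compound 3 both beyond the scatter.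

Compound 4 `CCO/N=C1/C(=O)N(CCCn2cc(CN3CCC[C@@H]4CN(c5c(F)cc6c(=O)c(C(=O)O)cn(C7CC7)c6c5OC)C[C@@H]43)nn2)c2ccc(F)cc21` has not yet been measured in this assay. It differs from compound 2 by methyl in place of hydrogen on a saturated chain carbon bound to an oxygen on an unsaturated carbon, which is the same change as that from compound 3 to compound 1; the two cores differ by fluoro in place of hydrogen on an aromatic carbon. Because no change at the digits printed from compound 3 to compound 1 (within the scatter), the step from compound 2 to compound 4 is expected to be small, no change at the digits printed from compound 2 to compound 4 (within the scatter). Compound 4 is therefore estimated at 4 ug/mL in this assay, with a range from 2 ug/mL to 10 ug/mL.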

Compound 4, half-maximal cytotoxic concentration: 4 ug/mL
Beside the measured number, compound 4's estimate shows no gap at the digits printed, and the stated range covers the measured number.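

In this assay, methyl in place of hydrogen, which turns methoxy into ethoxy, gives no change at the digits printed from compound 2 to compound 4 (within the scatter), and this step on the fluoro core agrees with the one on the core without the fluoro: the same change on two cores in this assay, no change at the digits printed (within the scatter) from compound 3 to compound 1 and no change at the digits printed (within the scatter) from compound 2 to compound 4, 1.0-fold (0.00 log units) apart, within the scatter of two such steps The fluoro change also carries over, giving a 4.0-fold lower number from compound 1 to compound 4 (0.60 log units; beyond the scatter), which agrees with the earlier step on the methoxy compounds: the same change on two cores in this assay, a 4.0-fold higher number (0.60 log units; beyond the scatter) from compound 2 to compound 3 and a 4.0-fold higher number (0.60 log units; beyond the scatter) from compound 4 to compound 1, 1.0-fold (0.00 log units) apart, within the scatter of two such steps Together these show that, among these four compounds, the two changes read the same whichever of the two cores carries them, but each rests on a single pair of steps, and the cores differ only by that fluoro, so nothing follows for a core that differs elsewhere and no reason for the lower number with fluoro is given.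

The compounds shown leave open whether a longer chain on the oxygen, such as propoxy, would keep this flat response. They also leave open whether chloro or methoxy on the aromatic carbon that carries the fluoro would lower the number as fluoro does.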